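The source may hold more compounds than are shown below. What is called first, only, known or untested is meant among the compounds shown, and "the series" means these compounds.

Compound 2 `C[C@@]1(O)[C@H](O)[C@@H](CO)O[C@H]1c1cnc2c(N)nc(F)nn12` shares its core with compound 1 `C[C@@]1(O)[C@H](O)[C@@H](CO)O[C@H]1c1cnc2c(N)nc(Cl)nn12`, the two differing only in fluoro in place of chloro on an aromatic carbon. In an ADME assay on Huh-7 cells (Homo sapiens) for cytotoxicity (on this read-out lower numbers stand for higher toxicity in this test and higher numbers for lower toxicity in this test), compound 1 gives > 100000 nM, which is a limit of the assay rather than a number. In this assay compound 2 likewise gives > 100000 nM, again a limit of the assay and not a number. The step that the two limits leave unreadable from compound 1 to compound 2 is therefore not readable in size, because both values sit at the limit of > 100000 nM in this assay, at which 2 of the 2 values shown sit. On the numbers shown, compound 2 thus stands at the limit of this assay, with no measured toxicity. Compound 3 `C[C@@]1(O)[C@H](O)[C@@H](CO)O[C@H]1c1cnc2c(N)nc(N)nn12` departs from compound 2 by amino in place of fluoro on an aromatic carbon. Within the data shown here, the only measured step in this assay bears on this change solely as a pattern of two limits, and its size is unreadable, so no step beyond the scatter is expected in either direction, and compound 3 is expected to remain at the limit. Compound 3 is estimated to give 150000 nM in this assay, within the range 80000 nM to 300000 nM. The step from compound 2 to compound 3 is expected to be a step that the limit leaves unreadable from compound 2 to compound 3.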

Compound 3, half-maximal cytotoxic concentration: > 100000 nM
Compound 3: only a limit was reported; the forecaster's own chance of this, stated with the estimate: 85%; the middle value is on the limit's open side.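

In this assay compound 3 gives > 100000 nM as a limit of the assay and not a number. No new step can be read between compound 3 and compound 1 or compound 2, because all three sit at the same limit: the limit of > 100000 nM in this assay, at which 3 of the 3 values shown sit. The compounds shown leave open how their toxicity in this test compares.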